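The compounds below may be only part of what the source reports. "The series", "measured", "known", "first", "only" and "open" are said of these compounds alone.

Measured so far in an ADME assay on MCF-10A cells (Homo sapiens) for cytotoxicity, read by MTT assay, with a stated time of 72 h; on this read-out higher numbers stand for weaker inhibition and lower numbers for stronger inhibition:
compound 1 `COc1ccc(-c2ccc(C)n2-c2ccc(-c3nc4ccccc4s3)cc2)cc1` gives 36300 nM
compound 2 `COc1cc(-c2ccc(C)n2-c2ccc(-c3nc4ccccc4s3)cc2)cc(OC)c1OC` gives 38800 nM
compound 3 `COc1cc(-c2ccc(C)n2-c2ccc(-c3nc4ccc(F)cc4s3)cc2)cc(OC)c1OC` gives 40000 nM

These three numbers lie within the usual scatter of one another, so compound 3 stands level with compound 2 and compound 1 rather than apart from them. Compound 4 `COc1ccc2nc(-c3ccc(-n4c(C)ccc4-c4cc(OC)c(OC)c(OC)c4)cc3)sc2c1` differs from compound 3 by methoxy in place of fluoro on an aromatic carbon. Going by the values given here, only one measured step touches that place on the fused ring, a 1.0-fold higher number from compound 2 to compound 3 (0.01 log units; within the scatter), and it stayed within the scatter. Among the compounds with values here, no measured step shows a methoxy entering there, so that single step is the only guide. Compound 4 is therefore expected to show no shift beyond the scatter, no change at the digits printed from compound 3 to compound 4 (within the scatter). Compound 4 is estimated at 40000 nM, with a range from 20000 nM to 80000 nM.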

Compound 4, half-maximal inhibitory concentration: 37800 nM
The estimate for compound 4 lay 1.1-fold (0.02 log units) above the measured number; the range from low to high includes it.
By their numbers in this assay, from the lowest: compounds 1, 4, 2 and 3 (each within the scatter of the next).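

In this assay, methoxy at this place on the fused ring gives a 1.1-fold lower number from compound 3 to compound 4 (0.02 log units; within the scatter) when it replaces fluoro and a 1.0-fold lower number from compound 2 to compound 4 (0.01 log units; within the scatter) when it replaces hydrogen. Fluoro was the only replacement tested here before, and now a second group, with an added oxygen and one hydrogen-bond acceptor, also stays within the scatter. No evidence bearing on this result is available. The compounds shown leave open whether an amine or a carboxylic acid here would move the number beyond the scatter. They also leave open whether a longer chain, such as butoxy, would do so.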